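Aryl hydrazone variation on the shared core

The compounds below may be only part of what the source reports. "The series", "measured", "known", "first", "only" and "open" are said of these compounds alone.

The series keeps the core of compound 1 `Cn1c(=O)c(=O)n(C2CCCC2)c2nc(N/N=C/c3ccc(O)c(F)c3)ncc21` and changes the aryl group on a carbon with a double bond to nitrogen. In a functional assay on A549 cells (Homo sapiens) for antiproliferative activity, read by MTT assay (a lower number here means a stronger inhibitor, a higher number a weaker inhibitor), compound 1 gives 97800 nM. Compound 2 `COc1cccc(/C=N/Nc2ncc3c(n2)n(C2CCCC2)c(=O)c(=O)n3C)c1` gives 27400 nM in this assay; the step is a 3.6-fold lower number from compound 1 to compound 2 (0.55 log units; beyond the scatter). Compound 3 `COc1ccc(/C=N/Nc2ncc3c(n2)n(C2CCCC2)c(=O)c(=O)n3C)c(OC)c1` is reported in this assay only as the limit > 100000 nM, so no number stands for it. This is the limit of > 100000 nM in this assay, at which 1 of the 3 values shown sits. Relative to compound 2 the step is an at least 3.6-fold higher number from compound 2 to compound 3 (0.56 log units; beyond the scatter); relative to compound 1 it is an at least 1.0-fold higher number from compound 1 to compound 3 (0.00 log units; that floor lies within the scatter).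

Compound 4 `Cn1c(=O)c(=O)n(C2CCCC2)c2nc(N/N=C/c3ccccc3Cl)ncc21` differs from compound 3 in one place: 2-chlorophenyl in place of 2,4-dimethoxyphenyl on a carbon with a double bond to nitrogen. Among the compounds with values here, no measured step exchanges a methoxy-bearing ring for a chlorine-bearing one, so the steps from compound 2 to compound 3 and from compound 1 to compound 3 bear on it only by showing the spread of aryl variants in this assay, from the number of compound 2 up to the limit of compound 3. Compound 3 stands at that limit, and for compound 4 the expected step is an at least 2.0-fold lower number from compound 3 to compound 4 (0.30 log units; that floor lies within the scatter), a return toward measured numbers rather than a large gain. Compound 4 is estimated at 50000 nM, with a range from 15000 nM to 150000 nM.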

Compound 4, half-maximal inhibitory concentration: 9860 nM
Estimate against measurement, compound 4: 5.1-fold (0.71 log units) above, outside the stated range (below it).
By their numbers in this assay, from the lowest: compound 4; then compound 2; then compound 1. At a limit, above all of these: compound 3.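

Working notes on the aryl position: in this assay the 2-chlorophenyl of compound 4 gives the lowest number of the series so far, clearing both the 3-methoxyphenyl (a 2.8-fold lower number from compound 2 to compound 4 (0.44 log units; beyond the scatter)) and the 3-fluoro-4-hydroxyphenyl (a 9.9-fold lower number from compound 1 to compound 4 (1.00 log units; beyond the scatter)). Measured change at this position therefore extends beyond the methoxy-bearing and hydroxy-bearing rings, and a ring with no hydrogen-bond acceptors under the count given for this group gives the lowest number among the four compounds. The exchange of 2,4-dimethoxyphenyl for 2-chlorophenyl gives the widest step read here (an at least 10-fold lower number from compound 3 to compound 4 (1.00 log units; beyond the scatter)), although compound 3 is only a limit in this comparison, so the true size of that step remains unfixed: the limit of > 100000 nM in this assay, at which 1 of the 4 values shown sits.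

The compounds shown do not tell whether the chlorine itself or its place on the ring goes with the lower number, since compound 4 is the only chlorine-bearing member here. From the compounds shown here alone, whether a bromine, a methyl or an amine on the same ring would give a lower number than compound 4 also remains open.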